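Swapping the alkyne substituent: expected tolerance on Vero cells

This account rests on a few compounds, and the source may have more. Where it says the series, first, only, none or still open, it means among the compounds named here.

Measured so far:
- compound 1 `O=c1[nH]c(=O)n([C@@H]2O[C@H](CO)[C@@H](O)[C@H]2O)cc1C#CC1CCCCC1`: 148000 nM
- compound 2 `CCCCC#Cc1cn([C@@H]2O[C@H](CO)[C@@H](O)[C@H]2O)c(=O)[nH]c1=O`: 103000 nM

Both compounds share one core and differ only in the group on the triple-bonded carbon. In an ADME assay on Vero cells (Chlorocebus sabaeus) for cytotoxicity, read by MTT assay (a lower number here means that less compound is tolerated, a higher number that more compound is tolerated), compound 1 gives 148000 nM, and compound 2 gives 103000 nM. Going by the values given here, the one measured step, a 1.4-fold lower number from compound 1 to compound 2 (0.16 log units; within the scatter), is within the scatter, so the two numbers cannot be told apart and compound 2 does not stand apart from compound 1 on this assay.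

Compound 3 `O=c1[nH]c(=O)n([C@@H]2O[C@H](CO)[C@@H](O)[C@H]2O)cc1C#CC(O)c1ccccc1` has not yet been measured. Its difference from compound 2 is hydroxy(phenyl)methyl in place of butyl on a triple-bonded carbon. Among the compounds with values here, the only measured step exchanges one chain for another without a hydroxyl or an aromatic ring, so it bears on this change only loosely; it shows that a change at this position left this assay essentially unmoved. Within the data shown here, no measured step tells what the entering hydroxy(phenyl)methyl does here.

The expected step is therefore a 1.1-fold lower number from compound 2 to compound 3 (0.04 log units; within the scatter), with nothing beyond the scatter foreseen. Compound 3 is estimated at 95000 nM in this assay, within a range of 35000 nM to 250000 nM.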

Compound 3, half-maximal cytotoxic concentration: 65400 nM
The estimate for compound 3 lay 1.5-fold (0.16 log units) above the measured number; the measured number falls inside the stated range.
By their numbers in this assay, from the lowest: compounds 3, 2 and 1 (each within the scatter of the next, the first and the last beyond it).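

In this assay, going by these compounds alone, a change on the triple-bonded carbon now moves the number beyond the scatter for the first time: the exchange of cyclohexyl for hydroxy(phenyl)methyl gives a 2.3-fold lower number from compound 1 to compound 3 (0.35 log units; beyond the scatter) and the size of this step is modest. The exchange of butyl for the same group gives a 1.6-fold lower number from compound 2 to compound 3 (0.20 log units; within the scatter) and stays within the scatter, so the new group stands apart from cyclohexyl but not from butyl, and compound 2 cannot be told apart from either of its neighbours in this small series. Within the data shown here, this position is therefore not wholly silent in this assay, yet the one clear step depends on which group is taken as the starting point, and nothing measured here tells what lies behind it.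

Hydroxy(phenyl)methyl brings a hydroxyl and an aromatic ring in together, so these compounds leave open which of the two, if either, goes with the lower number; a plain benzyl group, without the hydroxyl, and a hydroxybutyl chain, without the ring, would pull them apart. As far as these compounds go, how an amine or a carboxylic acid at the end of the chain would read in this assay also remains open.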